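The source may report more compounds than this note shows. Statements on the series, on what has been measured and on what is new or still open speak of the compounds shown alone.

Measured so far in a functional assay on HeLa cells (Homo sapiens) for inhibition, read by sulforhodamine B assay; a lower number here means a stronger inhibitor, a higher number a weaker inhibitor:

compound 1 `O=C1C=C(NCc2ccccc2)C(=O)c2c1nc1n2[C@H]2OC[C@@H](O)[C@H]2OC1` gives > 8000 nM, a limit of the assay.
compound 2 `COc1ccccc1NC1=CC(=O)c2c(nc3n2[C@H]2OC[C@@H](O)[C@H]2OC3)C1=O` gives 7460 nM.
compound 3 `O=C1C(N2CCCC2)=CC(=O)c2c1nc1n2[C@H]2OC[C@@H](O)[C@H]2OC1` gives > 16000 nM, a limit of the assay.

Compound 1 stands at a limit (the limit of > 8000 nM in this assay, at which 1 of the 3 values shown sits), so no number is known for it. Compound 3 stands at the other limit (the limit of > 16000 nM in this assay, at which 1 of the 3 values shown sits). Only compound 2 gives a number in this assay.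

Compound 4 `O=C1C=C(Nc2ccc(C(F)(F)F)cc2)C(=O)c2c1nc1n2[C@H]2OC[C@@H](O)[C@H]2OC1` differs from compound 1 by 4-(trifluoromethyl)phenyl in place of benzyl on an amine nitrogen. Going by the values given here, the only measured step, an at least 2.1-fold higher number from compound 2 to compound 3 (0.33 log units; beyond the scatter), swaps an arylamino for pyrrolidin-1-yl and bears on the new change only loosely; it shows that the arylamino compound 2 reaches a number where the pyrrolidine does not. Compound 4 is likewise an arylamine, so a number near that of compound 2 is expected, with a fair chance of a limit instead. Compound 4 is estimated at 9000 nM, range 3000 nM to 30000 nM, an expected step that the limit leaves unreadable from compound 1 to compound 4.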

Compound 4, half-maximal inhibitory concentration: > 8000 nM
Compound 4 ended at the assay's limit (the forecaster's own chance of this, stated with the estimate: 50%); the middle value lies beyond the limit too.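

Compound 4 gives > 8000 nM, a limit of the assay. Going by these compounds alone, compound 1 gives > 8000 nM, also a limit, so no step between the two can be read. The compounds shown leave open whether 4-(trifluoromethyl)phenyl or benzyl gives the stronger inhibitor.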